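Compound 2 to compound 3: azepan-1-yl enters

The source may hold more compounds than are shown below. What is called first, only, known or untested is meant among the compounds shown, and "the series" means these compounds.

In an ADME assay on HCT-116 cells (Homo sapiens) for cytotoxicity, read by CellTiter-Glo, with a stated time of 72 h (a lower number here means a stronger inhibitor, a higher number a weaker inhibitor), compound 1 (`Cc1cc(C)c(S(=O)(=O)N2CCC(N3CCC(c4ccccc4)CC3)CC2)c(C)c1`) gives > 5000 nM as a limit of the assay, not a number. Compound 2 (`Cc1cc(C)c(S(=O)(=O)N2CCC(N3CCC(CCO)CC3)CC2)c(C)c1`) gives > 5000 nM as a limit too. The measured series sits at one place (the limit of > 5000 nM in this assay, at which 2 of the 2 values shown sit). Compound 3 (`Cc1cc(C)c(S(=O)(=O)N2CCC(N3CCCCCC3)CC2)c(C)c1`) differs from compound 2 as follows (azepan-1-yl in place of 4-(2-hydroxyethyl)piperidin-1-yl on a saturated ring carbon). For the measured compounds named here, the one measured step (a step that the two limits leave unreadable from compound 1 to compound 2) has no readable size to carry over, so no step beyond the scatter and no direction is expected in this assay for this change. The estimated step (a step that the limit leaves unreadable from compound 2 to compound 3) reflects that expectation. Compound 3 is estimated at 6000 nM with an expected range of 2500 nM to 12000 nM and may come out only as a limit.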

Compound 3, half-maximal inhibitory concentration: > 5000 nM
Compound 3 was reported as a limit; the forecaster's own chance of this, stated with the estimate: 80%; the middle value lies beyond the limit too.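

Compound 2 and compound 3 both sit at a limit, not a number, so no step between them can be read: the limit of > 5000 nM in this assay, at which 3 of the 3 values shown sit.

The compounds shown leave open whether any change at this place gives a readable value.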